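Removing one trifluoromethyl from the urea aryl of compound 3

The source may report more compounds than this note shows. Statements on the series, on what has been measured and on what is new or still open speak of the compounds shown alone.

Measured compounds in a functional assay on A498 cells (Homo sapiens) for inhibition, read by sulforhodamine B assay, with a stated time of 48 h, tested at 10 uM; on this read-out lower numbers stand for a stronger effect and higher numbers for a weaker effect at the one concentration tested:
compound 1 `COc1cc(Cl)cc(-c2nn(-c3cccc(NC(=O)c4ccc(Cl)c(Cl)c4)c3)cc2-c2ccncc2)c1`: -0.94%
compound 2 `COc1cc(Cl)cc(-c2nn(-c3cccc(NC(=O)Nc4ccc(Cl)c(C(F)(F)F)c4)c3)cc2-c2ccncc2)c1`: -9.18%
compound 3 `COc1cc(Cl)cc(-c2nn(-c3cccc(NC(=O)Nc4cc(C(F)(F)F)cc(C(F)(F)F)c4)c3)cc2-c2ccncc2)c1`: -21.6%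

Compound 3 stands lowest of the three in this assay; its gap to compound 2 and to compound 1 lies beyond the scatter. For the measured compounds named here, the one single-place step known, a number 8.2 percentage points lower from compound 1 to compound 2 (within the scatter), sits within the scatter. Compound 4 `COc1cc(Cl)cc(-c2nn(-c3cccc(NC(=O)Nc4cccc(C(F)(F)F)c4)c3)cc2-c2ccncc2)c1` differs from compound 3 by hydrogen in place of trifluoromethyl on an aromatic carbon. Going by the values given here, no measured step removes a trifluoromethyl from the urea aryl, so the expectation rests on compound 2 and compound 3 alone: their values show a smaller aryl substitution going with a higher number. Compound 4 is therefore expected to lie somewhat higher than compound 3, estimated at -12% (range -26% to 2%), a step of a number 9.6 percentage points higher from compound 3 to compound 4 (within the scatter) in this assay, near the edge of the scatter.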

Compound 4, a percentage reported as activity, at one concentration (the size of the read-out at that concentration, not a potency): -6.74%
The estimate for compound 4 lay 5.3 percentage points below the measured number; measured number inside the range.
By their numbers in this assay, from the lowest: compound 3; then compounds 2, 4 and 1 (each within the scatter of the next).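

In this assay, for the compounds shown here, the trifluoromethyl on this aromatic carbon counts: hydrogen in its place gives a number 14.9 percentage points higher from compound 3 to compound 4 (beyond the scatter) and is the first single-place step to clear the scatter. Hydrogen in place of chloro gives a number 2.4 percentage points higher from compound 2 to compound 4 (within the scatter) and (3-(trifluoromethyl)phenyl)amino in place of 3,4-dichlorophenyl gives a number 5.8 percentage points lower from compound 1 to compound 4 (within the scatter) and so neither change separates its pair. No measured evidence bears on the reason for this difference between the steps. Open, from the compounds shown here alone, is how an amine or a carboxylic acid on this aromatic carbon would read against trifluoromethyl and hydrogen.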